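The source may report more compounds than this note shows. Statements on the series, on what has been measured and on what is new or still open speak of the compounds shown alone.

Measured so far in a functional assay on HT-1080 cells (Homo sapiens) for inhibition, read by sulforhodamine B assay, with a stated time of 48 h; a higher number here means a weaker inhibitor, a lower number a stronger inhibitor:
- compound 1 `CCNC(=O)Nc1ccc(/C=C\c2cc(C)cc(C)c2)cc1`: 15000 nM
- compound 2 `Cc1cc(C)cc(/C=C/c2ccc(N3CCNC3=O)cc2)c1`: > 20000 nM

Compound 2 has no exact number in this assay, and its > 20000 nM is a limit of the assay.

The next compound to be tested is compound 3 `CCNC(=O)Nc1ccc(/C=C/c2cc(C)cc(C)c2)cc1`. It carries (ethylcarbamoyl)amino in place of the 2-oxoimidazolidin-1-yl of compound 2, on an aromatic carbon para to a large group: (ethylcarbamoyl)amino in place of 2-oxoimidazolidin-1-yl on an aromatic carbon. Within the data shown here, no measured step yet shows what such a change does. Among the measured compounds shown here, the only guide is compound 1, which carries the same (ethylcarbamoyl)amino group and gives 15000 nM. A small move towards stronger inhibition is therefore expected, perhaps none beyond the usual scatter. The estimated change is an at least 1.3-fold lower number from compound 2 to compound 3 (0.12 log units; that floor lies within the scatter). For compound 3 the expected value is 15000 nM, with an estimated range from 6000 nM to 35000 nM.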

Compound 3, half-maximal inhibitory concentration: > 20000 nM
Compound 3: no number, only a limit (the forecaster's own chance of this, stated with the estimate: 40%); at least 1.3-fold (0.12 log units) between middle value and limit.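

In this assay, compound 3 gives > 20000 nM, which is a limit of the assay and not a number. The change from 2-oxoimidazolidin-1-yl to (ethylcarbamoyl)amino therefore cannot be read, since both compounds in that step stand at the same limit: the limit of > 20000 nM in this assay, at which 2 of the 3 values shown sit. Among these compounds, the one readable step is an at least 1.3-fold higher number from compound 1 to compound 3 (0.12 log units; that floor lies within the scatter), and it bears on the double bond alone, so the drawn Z and E forms may differ by much more than this floor or by no more than the usual scatter: the fact that compounds 1 and 3 differ only in the configuration as drawn.

From the compounds shown here alone, how far apart the Z and E forms really lie stays open, and so does the effect of the ring-closed versus open urea-type group. It is also unknown whether an amine or a carboxylic acid on this aromatic carbon would give an exact number in this assay.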